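Adding a Cyclohexyloxy Group to Compound 2

The source may hold more compounds than are shown below. What is called first, only, known or untested is meant among the compounds shown, and "the series" means these compounds.

Compound 2 `c1ccc2ncc(-c3nn[nH]n3)cc2c1` is the only one of the three measured compounds for which a functional assay on the whole organism (strain Sprague-Dawley) for inhibition, with Rattus norvegicus as the target (on this read-out lower numbers stand for an effect already at smaller amounts and higher numbers for an effect only at larger amounts of compound), gives a number: compound 2 gives 10 mg/kg. Compound 1 `FC(F)(F)c1ccc2cc(-c3nn[nH]n3)cnc2c1` carries a trifluoromethyl group in place of a hydrogen of that core; in this assay compound 1 sits at a limit of the assay, < 10 mg/kg. Compound 3 `Fc1cccc2cc(-c3nn[nH]n3)cnc12` carries a fluoro group in place of a hydrogen; in this assay compound 3 also sits at a limit, > 10 mg/kg. The step of a number no lower from compound 1 to compound 2 (the limit leaves the size open) and the step of a number no lower from compound 2 to compound 3 (the limit leaves the size open) therefore have no readable size; the limit of < 10 mg/kg in this assay, at which 1 of the 3 values shown sits, and the limit of > 10 mg/kg in this assay, at which 1 of the 3 values shown sits, tell only where the two limits lie.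

Compound 4 `c1cc2ncc(-c3nn[nH]n3)cc2cc1OC1CCCCC1` differs from compound 2 in one place: cyclohexyloxy in place of hydrogen on an aromatic carbon. Among the compounds with values here, no measured step puts a number on a change of this kind, so neither the direction nor the size of the step to compound 4 can be read from the three measured compounds, and any expectation rests on the number for compound 2 alone. Compound 4 is therefore estimated at 5 mg/kg, with a range from 1 mg/kg to 30 mg/kg. The expected step is then a 2.0-fold lower number from compound 2 to compound 4 (0.30 log units; within the scatter), and a further limit rather than a number would not be surprising.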

Compound 4, minimum effective dose: 5 mg/kg
Estimate against measurement, compound 4: no gap at the digits printed; the range from low to high includes it.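

In this assay, within the data shown here, the new step reads a 2.0-fold lower number from compound 2 to compound 4 (0.30 log units; within the scatter) and is the only step here with a readable size, while the steps involving compound 1 and compound 3 cannot be read. It shows that on this aromatic carbon, meta to a fused ring and para to a fused ring, hydrogen can be replaced by cyclohexyloxy, with its 7 heavy atoms and its six-membered non-aromatic ring of carbon only, and the read-out stays within the usual scatter of compound 2. Among these compounds, nothing measured here gives a reason for this result, so it records only that such a large change on this carbon leaves the number within the scatter.

The compounds shown leave open whether this holds for other groups on the same carbon, such as a methoxy group, an amine, a carboxylic acid or a longer chain joined through oxygen. They also leave open whether cyclohexyloxy would behave in the same way on the other aromatic carbons of the shared core, including those that carry trifluoromethyl in compound 1 and fluoro in compound 3.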